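A few compounds are considered here, and "the series" means these few. Any claim that something is new, unique, unknown or untested is made for them only; others in the source may bear on it.

Among the compounds with values here, in a functional assay on HeLa cells (Homo sapiens) for cytotoxicity, read by MTT assay, with a stated time of 24 h (a lower number here means a stronger inhibitor, a higher number a weaker inhibitor), three compounds have numbers so far. Compound 3 (`O=C(NC(=S)Nc1nc2cc([N+](=O)[O-])ccc2s1)c1ccccc1`) gives 75100 nM and this value lies within the scatter of the other two. Compound 1 (`O=C(NC(=S)Nc1nc2cc(Br)ccc2s1)c1cccs1`) gives 46500 nM in the same test, and compound 2 (`CCCCC(=O)NC(=S)Nc1nc2cc(Br)ccc2s1`) gives 60200 nM there.

Compound 4 (`O=C(NC(=S)Nc1nc2cc(Br)ccc2s1)c1ccccc1`) keeps the group on the carbonyl carbon of compound 3 and alters one substituent of the core, with bromo in place of nitro on an aromatic carbon so that it carries the bromo also found in compound 1 and compound 2. Within the data shown here, no measured step covers this exchange directly. Among the measured compounds shown here, the only step available is a 1.3-fold higher number from compound 1 to compound 2 (0.11 log units; within the scatter) and it concerns the group on the carbonyl carbon, with bromo held constant, so it bears on the new change only indirectly. Its small size, together with the closeness of all three values, gives no ground to expect a step beyond the scatter in this assay for this exchange. The expected change is a 1.4-fold lower number from compound 3 to compound 4 (0.14 log units; within the scatter) and this estimated step stays within the scatter. The estimate for compound 4 is 55000 nM with an expected range from 30000 nM to 95000 nM for repeated measurements.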

Compound 4, half-maximal inhibitory concentration: 64600 nM
Estimate against measurement, compound 4: 1.2-fold (0.07 log units) below; the measured number falls inside the stated range.
By their numbers in this assay, from the lowest: compounds 1, 2, 4 and 3 (each within the scatter of the next).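

In this assay, within the data shown here, the exchange of nitro for bromo on an aromatic carbon of the shared core, with phenyl held on the carbonyl carbon, gives a 1.2-fold lower number from compound 3 to compound 4 (0.07 log units; within the scatter) and so provides the first direct reading at this position, where the two groups are not separated even though nitro brings three heavy atoms and bromo one. With bromo held constant, compound 4 also links the group on the carbonyl carbon to phenyl through a 1.1-fold higher number from compound 2 to compound 4 (0.03 log units; within the scatter) and a 1.4-fold higher number from compound 1 to compound 4 (0.14 log units; within the scatter), so phenyl is not separated from either butyl or thiophen-2-yl in this test. Nothing at hand gives a measured reason for these values or for the absence of separation.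

The compounds shown leave open whether an amine or a methoxy group on this aromatic carbon, or a longer chain on the carbonyl carbon, would give a step beyond the scatter. They also leave open whether the exchange of nitro for bromo reads the same with butyl or thiophen-2-yl on the carbonyl carbon in place of phenyl.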